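Fluoro for bromo in the nitrophenyl series

The source may hold more compounds than are shown below. What is called first, only, known or untested is meant among the compounds shown, and "the series" means these compounds.

In a functional assay on DU-145 cells (Homo sapiens) for inhibition, read by trypan blue exclusion, with a stated time of 96 h (on this read-out lower numbers stand for stronger inhibition of growth and higher numbers for weaker inhibition of growth), compound 1 `O=C(O)c1ccc(C(=O)/C(=C\c2ccc(Br)c([N+](=O)[O-])c2)SCc2ccc(Cl)cc2)cc1` stands at a limit and not a number (< 1000 nM). In this assay compound 2 `O=C(O)c1ccc(C(=O)/C(=C\c2ccc(Br)c([N+](=O)[O-])c2)SCc2ccc(Cl)cc2Cl)cc1` gives 1000 nM and compound 3 `O=C(O)c1ccc(C(=O)/C(=C\c2ccc(Br)c([N+](=O)[O-])c2)SCc2ccc(Br)cc2)cc1` gives 1000 nM as measured numbers.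

Compound 4 `O=C(O)c1ccc(C(=O)/C(=C\c2ccc(F)c([N+](=O)[O-])c2)SCc2ccc(Cl)cc2)cc1` differs from compound 1 by one change (fluoro in place of bromo on an aromatic carbon): fluoro in place of bromo on an aromatic carbon, ortho to a nitro group.

Going by the values given here, no measured step touches this position. All three concern the group on the saturated chain carbon bound to a sulfur. Two of them (a number no lower from compound 1 to compound 2 (the limit leaves the size open) and a number no lower from compound 1 to compound 3 (the limit leaves the size open)) have sizes left open by the limit. The third (no change at the digits printed from compound 2 to compound 3 (within the scatter)) lies within the scatter.

With compound 3 at 1000 nM as the nearest measured number, no step beyond the scatter is expected, in either direction. The estimate amounts to a step that the limit leaves unreadable from compound 1 to compound 4 and is expected to stay within the scatter. Estimated for compound 4 is 800 nM with an expected range from 300 nM to 2000 nM in this series.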

Compound 4, concentration for 50% growth inhibition: 50000 nM
Compound 4: the middle estimate sits 63-fold (1.80 log units) below what was measured, outside the stated range (above it).
By their numbers in this assay, from the lowest: compounds 2 and 3 (each within the scatter of the next); then compound 4.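

In this assay this aromatic carbon, ortho to a nitro group, is the first position shown to carry a large effect: going from 4-bromo-3-nitrophenyl to 4-fluoro-3-nitrophenyl gives an at least 50-fold higher number from compound 1 to compound 4 (1.69 log units; beyond the scatter). The earlier steps shown here all concern the group on the saturated chain carbon bound to a sulfur; those starting at compound 1 cannot be read, and the remaining one shows no change at the digits printed from compound 2 to compound 3 (within the scatter). Compound 1 stands at a limit, so the new step has a floor and no fixed size: the limit of < 1000 nM in this assay, at which 1 of the 4 values shown sits.

From the compounds shown here alone, what an amine or a methoxy group would give on this aromatic carbon stays open, as does the place of a chloro group there relative to bromo and fluoro. Also open, going by these compounds, is whether the step carries over to the 2,4-dichlorophenyl and 4-bromophenyl groups of compound 2 and compound 3.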